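A Chlorine Added to the Two-Ring Core of Compound 2

The source may report more compounds than this note shows. Statements on the series, on what has been measured and on what is new or still open speak of the compounds shown alone.

Of the compounds shown here, three have been tested in a functional assay on MCF7 cells (Homo sapiens) for cytotoxicity, read by MTT assay, with a stated time of 48 h; on this read-out higher numbers stand for weaker inhibition and lower numbers for stronger inhibition. Compound 1 `[O-][S+](CCC(F)=C(F)F)c1ncc(-c2ccncc2)s1` carries a fluorinated chain on a sulfoxide joined to a small core. In this assay compound 1 reaches only a limit, > 120000 nM, so no number is known for it; its result is the limit of > 120000 nM in this assay, at which 1 of the 3 values shown sits. Compound 2 `[O-][S+](CCC(F)(Cl)C(F)(F)Cl)c1nc2ccccc2s1` has a chlorinated and fluorinated chain on a sulfoxide joined to a two-ring core, and in this assay compound 2 gives 17100 nM. Compound 3 `O=S(=O)(CCC(F)(Cl)C(F)(F)Cl)c1nc2ccc(Cl)cc2s1` pairs the same chain with a sulfone and a chlorine on the two-ring core, and in this assay compound 3 gives 8400 nM. Of the two numbers shown, compound 2 stands highest, and its gap to compound 3 lies beyond the usual scatter.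

Compound 4 `[O-][S+](CCC(F)(Cl)C(F)(F)Cl)c1nc2ccc(Cl)cc2s1` has not yet been measured. It differs from compound 2 by chloro in place of hydrogen on an aromatic carbon, while the sulfoxide is kept. For the measured compounds named here, no measured pair shows this change alone, so its size is uncertain. Compound 3 carries the same chlorine together with the sulfone and gives 8400 nM, which hints at a move toward a lower number rather than a large shift. The expected step from compound 2 to compound 4 is a 1.7-fold lower number from compound 2 to compound 4 (0.23 log units; within the scatter), a modest drop near the edge of the scatter. Compound 4 is therefore estimated at 10000 nM, with a likely range from 4000 nM to 25000 nM.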

Compound 4, half-maximal inhibitory concentration: 12200 nM
Compound 4: the middle estimate sits 1.2-fold (0.09 log units) below what was measured, within the range that was stated.
By their numbers in this assay, from the lowest: compounds 3, 4 and 2 (each within the scatter of the next, the first and the last beyond it). At a limit, above all of these: compound 1.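

In this assay, for the compounds shown here, this is the first pair in which chloro in place of hydrogen on an aromatic carbon can be read alone, with the sulfoxide kept: the chlorine sits on a six-membered aromatic ring of carbon only, part of a fused system of two rings, and the result is a 1.4-fold lower number from compound 2 to compound 4 (0.15 log units; within the scatter). This position therefore accepts a chlorine without a clear change in the read-out, and the two compounds cannot be told apart here. Compound 4 also allows sulfoxide and sulfone to be set side by side on the chlorinated core, where compound 4 gives 12200 nM and compound 3 gives 8400 nM, two values within the scatter of each other, and nothing shown offers a reason for either result.

The compounds shown leave open whether a different group on this same aromatic carbon, such as an amine, a methoxy group or a carboxylic acid, would move the number beyond the scatter. They also leave open what a longer chain on the sulfoxide would do with the chlorine in place.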